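A few compounds are considered here, and "the series" means these few. Any claim that something is new, unique, unknown or untested is made for them only; others in the source may bear on it.

Three compounds share a core in which a chloro-substituted aryloxyacetic acid is joined through an alkyne to a second aromatic ring, and all three were tested in an assay on CHO cells for displacement of a labelled ligand from prostaglandin D2 receptor 2 (Homo sapiens), read by scintillation counting; a higher number here means a weaker inhibitor, a lower number a stronger inhibitor. Compound 1, `Cc1ccc(S(=O)(=O)Cc2ccccc2)cc1C#Cc1cc(Cl)ccc1OCC(=O)O`, carries a benzylsulfonyl group on that second ring and gives 5 nM. Compound 2, `CCCc1ccncc1C#Cc1cc(Cl)ccc1OCC(=O)O`, replaces the second ring with a propyl-bearing pyridine and gives 4.3 nM, a number so close to that of compound 1 that the two cannot be told apart by this assay. Compound 3, `COC1c2ccc(C#Cc3cc(Cl)ccc3OCC(=O)O)cc2S(=O)(=O)C1(C)C`, in which the sulfonyl sits inside a fused saturated ring, gives 21 nM, the highest of the three and clearly weaker than compound 1.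

Compound 4, `CCS(=O)(=O)c1ccc(C)c(C#Cc2cc(Cl)ccc2OCC(=O)O)c1`, has not been measured. It differs from compound 1 by methyl in place of phenyl on a saturated chain carbon bound to a sulfonyl sulfur; read one bond further out, a benzylsulfonyl becomes an ethylsulfonyl. Among the measured compounds shown here, no measured pair shows a change of this kind, so the expectation rests on how little the measured numbers move when the sulfonyl group is kept. The step of a 1.6-fold higher number from compound 1 to compound 4 (0.20 log units; within the scatter) is expected to stay within the scatter or rise only slightly. Compound 4 is therefore estimated at 8 nM, within a range from 2.5 nM to 25 nM.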

Compound 4, inhibition constant: 8.6 nM
Beside the measured number, compound 4's estimate is 1.1-fold (0.03 log units) below it; low and high end bracket the measured number.
By their numbers in this assay, from the lowest: compounds 2, 1 and 4 (each within the scatter of the next); then compound 3.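

In this assay, among the compounds shown here, the first direct comparison at this position, replacing phenyl with methyl on the saturated chain carbon bound to the sulfonyl sulfur gives a 1.7-fold higher number from compound 1 to compound 4 (0.24 log units; within the scatter). The benzylsulfonyl and ethylsulfonyl compounds therefore cannot be told apart in this assay, which shows that, with the rest of compound 1 unchanged, the aromatic ring at the end of this group can be lost without a change beyond the scatter. Nothing else measured here helps explain this result.

The compounds shown leave open how a longer chain, such as propyl, or a chain ending in an amine would fare at this position. They also leave open what would happen if a carbonyl took the place of the sulfonyl while the ethyl group stayed.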